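Bromo to Methyl on the Shared Core of Compound 2

The compounds below may be only part of what the source reports. "The series", "measured", "known", "first", "only" and "open" are said of these compounds alone.

Of the compounds shown here, three sharing one core have been measured in a functional assay on MCF7 cells (Homo sapiens) for cytotoxicity, read by MTT assay, with a stated time of 24 h; a higher number here means a weaker inhibitor, a lower number a stronger inhibitor. Compound 1, `FC(F)(F)C(F)(F)C(F)(F)C(F)(F)C(F)(F)C(F)(F)CCn1cc(COc2ccccc2-c2nc3ccccc3s2)nn1`, gives 19800 nM in this assay. Compound 2, `Brc1ccc(-c2cc(COc3ccccc3-c3nc4ccccc4s3)on2)cc1`, gives 20000 nM. Compound 3, `FC(F)(F)c1cccc(-n2cc(COc3ccccc3-c3nc4ccccc4s3)nn2)c1`, gives 18900 nM. Among the compounds with values here, the value of compound 2 lies within the scatter of both of the others: the gap to compound 1 and the gap to compound 3 are each too small to separate the three, so nothing about the substituents on these side arms can be read from the numbers so far.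

Compound 4, `Cc1ccc(-c2cc(COc3ccccc3-c3nc4ccccc4s3)on2)cc1`, differs from compound 2 in a single place: methyl in place of bromo on an aromatic carbon. Put more fully, this is methyl in place of bromo on an aromatic carbon, on a six-membered aromatic ring of carbon only, at the position para to a large group, so that a 4-bromophenyl becomes a 4-methylphenyl.

Within the data shown here, no pair of measured compounds shows this exact step, so its size is unknown. Since the three measured compounds give values that are all within the scatter of one another despite different side arms, the expectation is that the step from compound 2 to compound 4 will also stay within the scatter, with no clear direction, as no change at the digits printed from compound 2 to compound 4 (within the scatter). Compound 4 is therefore estimated at 20000 nM in this assay, with a range from 10000 nM to 40000 nM.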

Compound 4, half-maximal inhibitory concentration: 27500 nM
For compound 4 the middle estimate is 1.4-fold (0.14 log units) below the measured one, within the range that was stated.
By their numbers in this assay, from the lowest: compounds 3, 1, 2 and 4 (each within the scatter of the next).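

In this assay the exchange of bromo for methyl on the six-membered aromatic ring of carbon only is now a step that can be read on its own, a 1.4-fold higher number from compound 2 to compound 4 (0.14 log units; within the scatter), and the 4-bromophenyl and the 4-methylphenyl cannot be told apart at this position. The earlier compounds shown here differed in whole side arms and offered no such single change, whereas this pair isolates one group: each of the two groups counts one heavy atom, with no ring, no hydrogen-bond donors or acceptors and no net charge, and the exchange leaves the number within the scatter. No supporting evidence bears on this result, so the pair gives a size for the step and nothing beyond it.

The compounds shown leave open whether a group of another kind on this aromatic carbon, such as an amine, a carboxylic acid or a longer chain like butyl, would give a step beyond the scatter in this assay. Within the data shown here, they also leave open whether a change at any other place on the shared core would do so, as this remains the only single change that can be read.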